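Hydantoin benzylidenes: acid to pyrrolidine amide at the anilide

The compounds below may be only part of what the source reports. "The series", "measured", "known", "first", "only" and "open" are said of these compounds alone.

Measured so far in a functional assay on NCI-H292 cells (Homo sapiens) for antiproliferative activity; on this read-out lower numbers stand for stronger inhibition and higher numbers for weaker inhibition:
compound 1 `COc1ccc(/C=C2\NC(=O)N(c3ccc(Cl)cc3)C2=O)cc1` gives 32100 nM.
compound 2 `CCOC(=O)c1ccc(N2C(=O)N/C(=C\c3ccc(O)cc3)C2=O)cc1` gives > 200000 nM, which is a limit of the assay.
compound 3 `O=C(O)c1cccc(N2C(=O)N/C(=C\c3ccc(O)cc3)C2=O)c1` gives > 200000 nM, which is a limit of the assay.

Compound 3 therefore stands at the floor of the numbers shown: its value is a limit, not a number, and it shares that position with compound 2, as the limit of > 200000 nM in this assay, at which 2 of the 3 values shown sit, makes plain. Only compound 1 returns a measured value in this assay, and all three share the benzylidene hydantoin core.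

Compound 4 `O=C(c1cccc(N2C(=O)N/C(=C\c3ccc(O)cc3)C2=O)c1)N1CCCC1` is the next member. It differs from compound 3 in one place: pyrrolidin-1-yl in place of hydroxy on a carbonyl carbon. Among the compounds with values here, no measured pair in the set isolates this change, so no step can be read off; what is known is only that the two hydroxyphenyl compounds, compound 2 and compound 3, sit at the limit, while compound 1, with methoxy and chloro substituents, is measurable. Given that, compound 4 is expected to remain weak, with a fair chance of another limit in this assay, though a return into the measurable range cannot be ruled out. The step from compound 3 to compound 4 is expected to be an at least 1.6-fold lower number from compound 3 to compound 4 (0.22 log units; that floor lies within the scatter). Compound 4 is estimated at 120000 nM, within 20000 nM to 600000 nM.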

Compound 4, half-maximal inhibitory concentration: > 200000 nM
Compound 4: only a limit was reported (the forecaster's own chance of this, stated with the estimate: 50%); middle value at least 1.6-fold (0.22 log units) from the limit.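

In this assay compound 4 gives > 200000 nM, which is a limit of the assay. Compound 3 is also reported only as a limit, so no step can be read between compound 3 and compound 4: the limit of > 200000 nM in this assay, at which 3 of the 4 values shown sit. The compounds shown leave open whether any replacement of hydroxy on this carbonyl carbon would return a measurable value.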